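Lengthening an ester chain in a cytotoxicity series

The compounds below may be only part of what the source reports. "The series", "measured", "known", "first", "only" and "open" are said of these compounds alone.

Four compounds share one core and differ only in the length of a saturated chain attached through an oxygen next to a carbonyl group. Compound 1 `CCCCCCOC(=O)CCC(=O)N1CCN(CCCOc2cc3c(Nc4ccc(F)c(Cl)c4)ncnc3cc2OC)CC1` carries the shortest chain; compound 2 `CCCCCCCOC(=O)CCC(=O)N1CCN(CCCOc2cc3c(Nc4ccc(F)c(Cl)c4)ncnc3cc2OC)CC1` differs from it by methyl in place of hydrogen on a saturated chain carbon, six bonds along the chain from an oxygen next to a carbonyl group; compound 3 `CCCCCCCCCOC(=O)CCC(=O)N1CCN(CCCOc2cc3c(Nc4ccc(F)c(Cl)c4)ncnc3cc2OC)CC1` differs from compound 1 by propyl in place of hydrogen on a saturated chain carbon, six bonds along the chain from an oxygen next to a carbonyl group; compound 4 `CCCCCCCCCCOC(=O)CCC(=O)N1CCN(CCCOc2cc3c(Nc4ccc(F)c(Cl)c4)ncnc3cc2OC)CC1` is not yet measured.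

In a functional assay on A549 cells (Homo sapiens) for cytotoxicity, read by MTT assay, with a stated time of 24 h, tested at 20 uM (a higher number here means a weaker effect of the compound at the concentration tested, a lower number a stronger effect), compound 1 gives 85.1%. Compound 2 gives 79.9%, so the step is a number 5.2 percentage points lower from compound 1 to compound 2 (within the scatter). Compound 3 gives 79.7%, with a number 5.4 percentage points lower from compound 1 to compound 3 (within the scatter) and a number 0.2 percentage points lower from compound 2 to compound 3 (within the scatter). All three numbers sit within the usual scatter of one another, so no ordering among them can be claimed.

Compound 4 differs from compound 3 by methyl in place of hydrogen on a saturated chain carbon, nine bonds along the chain from an oxygen next to a carbonyl group. This is the same kind of change as from compound 1 to compound 2, but it sits nine bonds along the chain rather than six. Because a number 5.2 percentage points lower from compound 1 to compound 2 (within the scatter) stayed within the scatter, the expected step for compound 4 is a number 1.7 percentage points lower from compound 3 to compound 4 (within the scatter). Compound 4 is therefore estimated at 78%, expected between 67% and 89% in this assay.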

Compound 4, a percentage reported as activity, at one concentration (the size of the read-out at that concentration, not a potency): 88.2%
The estimate for compound 4 lay 10.2 percentage points below the measured number; the measured number falls inside the stated range.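

In this assay, the methyl step further out on the chain is a number 8.5 percentage points higher from compound 3 to compound 4 (within the scatter), and set beside the same change made closer in, it shows no real difference: the same change on two cores in this assay, a number 5.2 percentage points lower (within the scatter) from compound 1 to compound 2 and a number 8.5 percentage points higher (within the scatter) from compound 3 to compound 4, 13.7 percentage points apart, within the scatter of two such steps The propyl change reads the same way, with a new step of a number 8.3 percentage points higher from compound 2 to compound 4 (within the scatter) set beside the earlier one: the same change on two cores in this assay, a number 5.4 percentage points lower (within the scatter) from compound 1 to compound 3 and a number 8.3 percentage points higher (within the scatter) from compound 2 to compound 4, 13.7 percentage points apart, within the scatter of two such steps So these steps give no sign that the change behaves differently from one chain length to another, but they do not show that it carries over reliably either: every step lies within the scatter, including a number 3.1 percentage points higher from compound 1 to compound 4 (within the scatter), so the opposite directions cannot be read as a reversal, and no effect of chain length can be claimed from these four compounds.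

The compounds shown all carry an unbranched saturated chain, so a chain ending in an amine or a carboxylic acid remains open. Going by these compounds, whether a phenyl ring in place of the chain would give a step beyond the scatter also remains open.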